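The compounds below may be only part of what the source reports. "The series", "measured", "known", "first", "only" and "open" are said of these compounds alone.

Measured compounds:
compound 1 `COc1ccc(-c2ccnc(C(=O)Nc3ccc(Oc4ccnc5[nH]ccc45)cc3)c2)cc1` gives 8210 nM in a functional assay on MCF7 cells (Homo sapiens) for cytotoxicity, read by MTT assay, with a stated time of 72 h; a lower number here means a stronger inhibitor, a higher number a weaker inhibitor
compound 2 `O=C(Nc1ccc(Oc2ccnc3[nH]ccc23)cc1)c1cc(-c2ccc(C(F)(F)F)cc2)ccn1` reaches only a limit in this assay, > 10000 nM
compound 3 `Cc1cccc(-c2ccnc(C(=O)Nc3ccc(Oc4ccnc5[nH]ccc45)cc3)c2)c1` gives 7470 nM in this assay

Of the two numbers shown in this assay, compound 3 gives the lowest, though the step of a 1.1-fold lower number from compound 1 to compound 3 (0.04 log units; within the scatter) lies within the scatter. Compound 4 `O=C(Nc1ccc(Oc2ccnc3[nH]ccc23)cc1)c1cc(-c2ccccc2)ccn1` differs from compound 3 by hydrogen in place of methyl on an aromatic carbon. The measured steps that bear on this all exchange the substituent on the pendant phenyl: a 1.1-fold lower number from compound 1 to compound 3 (0.04 log units; within the scatter), an at least 1.2-fold higher number from compound 1 to compound 2 (0.08 log units; that floor lies within the scatter) and an at least 1.3-fold lower number from compound 2 to compound 3 (0.12 log units; that floor lies within the scatter), none of them beyond the scatter, the latter two resting on (the limit of > 10000 nM in this assay, at which 1 of the 3 values shown sits). A further change of this kind is therefore expected to give no step beyond the scatter in this assay, a 1.1-fold higher number from compound 3 to compound 4 (0.03 log units; within the scatter). Compound 4 is expected at 8000 nM, with a range from 4000 nM to 16000 nM.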

Compound 4, half-maximal inhibitory concentration: 3750 nM
Compound 4: the middle estimate sits 2.1-fold (0.33 log units) above what was measured; the measured number lies below the stated range.
By their numbers in this assay, from the lowest: compounds 4, 3 and 1 (each within the scatter of the next, the first and the last beyond it). At a limit, above all of these: compound 2.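

Hydrogen on the pendant phenyl gives the first steps in this series that pass the scatter in this assay, both modest in size (a 2.2-fold lower number from compound 1 to compound 4 (0.34 log units; beyond the scatter)) and (an at least 2.6-fold lower number from compound 2 to compound 4 (0.42 log units; beyond the scatter)). Against methyl, the step stays within the scatter (a 2.0-fold lower number from compound 3 to compound 4 (0.30 log units; within the scatter)), so compound 3 and compound 4 cannot be ordered. The value of compound 2 is a limit, so its step gives only a floor: the limit of > 10000 nM in this assay, at which 1 of the 4 values shown sits.

Open, on these data alone, is how an amine or a carboxylic acid on the pendant phenyl would read in this assay. Also open, as far as these compounds go, is whether a change to the shared core would move the number further.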